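A few compounds are considered here, and "the series" means these few. Any claim that something is new, unique, unknown or untested is made for them only; others in the source may bear on it.

Three compounds share one core and differ only in the group on the benzyl ring. In a functional assay on cells for positive allosteric modulation of G-protein coupled receptor 68 (Homo sapiens), read by a luciferase reporter and cAMP accumulation, with a stated time of 30 min, at pH 6.8 and pH 8.3, in the presence of a further agent that is not named here (a higher number here means a more potent compound, by a factor of ten per unit of this negative logarithm, a lower number a less potent compound), compound 1 `Nc1nc(NCc2ccccc2)nc(-c2ccccc2CO)n1` gives 4.35, compound 2 `Nc1nc(NCc2ccc(C(F)(F)F)cc2)nc(-c2ccccc2CO)n1` gives 5.03 and compound 3 `COc1ccc(CNc2nc(N)nc(-c3ccccc3CO)n2)cc1` gives 3.34. Compound 3 thus stands lowest of the three, with a number 1.01 log units lower from compound 1 to compound 3 (beyond the scatter) and a number 1.69 log units lower from compound 2 to compound 3 (beyond the scatter), while the other measured step is a number 0.68 log units higher from compound 1 to compound 2 (beyond the scatter). Compound 4 `CC(C)Oc1ccc(CNc2nc(N)nc(-c3ccccc3CO)n2)cc1` is made from compound 3 by the change (isopropyl in place of methyl on an oxygen on an aromatic ring). Among the compounds with values here, none of the measured steps alters the group already on that oxygen, so nothing bears directly on this change; the three steps only show that exchanges on the aromatic carbon itself move the numbers in this assay by large amounts in either direction. Without a direct precedent a step of modest size is expected, and the direction is uncertain, so for compound 4 the expected step is a number 0.26 log units higher from compound 3 to compound 4 (within the scatter). In this assay compound 4 is estimated at 3.6, within 2.9 to 4.4.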

Compound 4, negative logarithm of the antagonist equilibrium constant: 4.99
Estimate against measurement, compound 4: 1.39 log units below, and the stated range ends below it.
By their numbers in this assay, from the lowest: compound 3; then compound 1; then compounds 4 and 2 (each within the scatter of the next).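

The group on the oxygen proves to matter as much as the exchanges on the aromatic carbon: in this assay the change from methyl to isopropyl gives a large step (a number 1.65 log units higher from compound 3 to compound 4 (beyond the scatter)), which more than recovers what methoxy lost against hydrogen (a number 0.64 log units higher from compound 1 to compound 4 (beyond the scatter)). Isopropoxy and trifluoromethyl on the same aromatic carbon cannot be told apart (a number 0.04 log units lower from compound 2 to compound 4 (within the scatter)), so two quite different groups reach the same level. Within the data shown here, nothing given here explains why this small enlargement of the group moves the number so far.

The compounds shown leave open whether an ethyl group on that oxygen would give an intermediate number, and whether a longer chain such as butyl would carry the rise further. They also leave open how an amine or a carboxylic acid would read on that aromatic carbon.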